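Tert-butyl in Place of the Amide Aryl Group

A few compounds are considered here, and "the series" means these few. Any claim that something is new, unique, unknown or untested is made for them only; others in the source may bear on it.

compound 1 `CCCCCCCCCCCCn1nnc(C(C(=O)Nc2ncccc2C)c2ccccc2)n1`: 4%
compound 2 `CCCCCCCCCCCCn1nnc(C(C(=O)Nc2c(OC)ncnc2OC)c2ccccc2)n1`: 39%
compound 3 `CCCCCCCCCCCCn1nnc(C(C(=O)Nc2c(C)nn(C)c2C)c2ccccc2)n1`: 66%

In an assay on isolated protein for inhibition of sterol O-acyltransferase 1 (Mus musculus), tested at 0.1 uM (a higher number here means more inhibition at the concentration tested (going by the name of the read-out), a lower number less inhibition), compound 3 stands highest of the three measured compounds, compound 2 nearest and compound 1 furthest: a number 27 percentage points higher from compound 2 to compound 3 (beyond the scatter) and a number 62 percentage points higher from compound 1 to compound 3 (beyond the scatter). Compound 4 `CCCCCCCCCCCCn1nnc(C(C(=O)NC(C)(C)C)c2ccccc2)n1` differs from compound 3 in one place: tert-butyl in place of 1,3,5-trimethyl-1H-pyrazol-4-yl on an amide-type nitrogen. Among the compounds with values here, no measured step exchanges an aromatic group for a chain, so none bears on this change directly. Within the data shown here, the three measured steps, a number 35 percentage points higher from compound 1 to compound 2 (beyond the scatter), a number 62 percentage points higher from compound 1 to compound 3 (beyond the scatter) and a number 27 percentage points higher from compound 2 to compound 3 (beyond the scatter), show only that the group on the amide nitrogen shifts the read-out by modest to large amounts. A downward step of uncertain size is therefore expected, a number 36 percentage points lower from compound 3 to compound 4 (beyond the scatter). Compound 4 is estimated at 30%, ranging from 5% to 62%.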

Compound 4, a percentage reported as inhibition, at one concentration (the size of the read-out at that concentration, not a potency): 1%
The estimate for compound 4 lay 29 percentage points above the measured number; the whole stated range lies above it.
By their numbers in this assay, from the lowest: compounds 4 and 1 (each within the scatter of the next); then compound 2; then compound 3.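

In this assay, tert-butyl on the amide-type nitrogen costs a great deal against two of the aromatic groups: a number 65 percentage points lower from compound 3 to compound 4 (beyond the scatter) and a number 38 percentage points lower from compound 2 to compound 4 (beyond the scatter). Against the third, a number 3 percentage points lower from compound 1 to compound 4 (within the scatter), so 3-methylpyridin-2-yl and tert-butyl cannot be told apart here, and an aromatic ring at this position does not by itself lift the read-out. The compounds shown come with no measurement that accounts for this. From the compounds shown here alone, it remains open whether a cyclohexyl ring, which has no aromatic ring, or a phenyl ring would match 1,3,5-trimethyl-1H-pyrazol-4-yl or fall to tert-butyl's level.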